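The compounds below may be only part of what the source reports. "The series", "measured", "known", "first", "only" and "open" are said of these compounds alone.

Compound 3 `Cc1ccoc1C1C(C#N)=C(N)N(c2ccc(S(N)(=O)=O)cc2)C2=C1C(=O)CCC2` stands, with compound 2 `COc1ccc(C2C(C#N)=C(N)N(c3ccc(S(N)(=O)=O)cc3)C3=C2C(=O)CCC3)c2ccccc12`, at the bottom of three numbers: in a functional assay on Ehrlich cells (Mus musculus) for antiproliferative activity, read by trypan blue exclusion, with a stated time of 2 h, tested at 25 ug/mL (on this read-out higher numbers stand for a stronger effect at the one concentration tested and lower numbers for a weaker effect), compound 3 gives 10%, while compound 2 gives 10%, and no change at the digits printed from compound 2 to compound 3 (within the scatter). Compound 1 `N#CC1=C(N)N(c2ccc(S(N)(=O)=O)cc2)C2=C(C(=O)CCC2)C1c1ccccc1` gives 30%; from there, a number 20 percentage points lower from compound 1 to compound 2 (beyond the scatter). Compound 4 `N#CC1=C(N)N(c2ccc(S(N)(=O)=O)cc2)C2=C(C(=O)CCC2)C1c1cccs1` differs from compound 3 by thiophen-2-yl in place of 3-methylfuran-2-yl on a saturated ring carbon. Within the data shown here, the two measured steps that reach compound 3 are a modest fall, a number 20 percentage points lower from compound 1 to compound 3 (beyond the scatter), and a flat pair, no change at the digits printed from compound 2 to compound 3 (within the scatter); neither involves thiophen-2-yl, so no measured step directly speaks to the new group. Compound 4 is therefore expected to stay close to compound 3, with a number 5 percentage points higher from compound 3 to compound 4 (within the scatter) expected to remain inside the scatter. The estimate for compound 4 is 15%, expected to fall between 5% and 30%.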

Compound 4, a percentage reported as activity, at one concentration (the size of the read-out at that concentration, not a potency): 80%
Estimate against measurement, compound 4: 65 percentage points below; measured number above the stated range.
By their numbers in this assay, from the lowest: compounds 2 and 3 (each within the scatter of the next); then compound 1; then compound 4.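

At the saturated ring carbon in this assay, thiophen-2-yl brings a large rise, with a number 70 percentage points higher from compound 3 to compound 4 (beyond the scatter) and a number 70 percentage points higher from compound 2 to compound 4 (beyond the scatter). It also overtakes phenyl, with a number 50 percentage points higher from compound 1 to compound 4 (beyond the scatter), so this position can carry a group that lifts the number over phenyl, which no earlier step had shown. No evidence here accounts for the difference between these groups. Thiophen-2-yl differs from 3-methylfuran-2-yl in both its ring heteroatom and the methyl group, so the source of the rise stays open. Unsubstituted furan-2-yl or 3-methylthiophen-2-yl would separate the two, and thiophen-3-yl would test the point of attachment.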